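Nitrophenyl ketone in the bromobenzyl thioether series

This account rests on a few compounds, and the source may have more. Where it says the series, first, only, none or still open, it means among the compounds named here.

Compound 2 `O=C(/C(=C\c1ccc(O)c([N+](=O)[O-])c1)SCc1ccc(Br)cc1)c1c(F)c(F)c(F)c(F)c1F` carries 2,3,4,5,6-pentafluorophenyl on the carbonyl carbon; in a functional assay on DU-145 cells (Homo sapiens) for inhibition, read by trypan blue exclusion, with a stated time of 96 h (on this read-out higher numbers stand for weaker inhibition of growth and lower numbers for stronger inhibition of growth), compound 2 gives 10000 nM. This is the highest of the two plain numbers in the set. Compound 1 `O=C(/C(=C\c1ccc(O)c([N+](=O)[O-])c1)SCc1ccc(Br)cc1)c1ccc(O)cc1O` gives only a limit, > 100000 nM, in this assay, as noted in the limit of > 100000 nM in this assay, at which 1 of the 3 values shown sits. Compound 3 `O=C(/C(=C\c1ccc(O)c([N+](=O)[O-])c1)Sc1ccc(Br)cc1)c1c(F)c(F)c(F)c(F)c1F` gives 1000 nM in this assay. Of the measured steps, an at least 10-fold lower number from compound 1 to compound 2 (1.00 log units; beyond the scatter) concerns the same carbonyl carbon and a 10-fold lower number from compound 2 to compound 3 (1.00 log units; beyond the scatter) concerns the sulfur. Compound 4 `O=C(/C(=C\c1ccc(O)c([N+](=O)[O-])c1)SCc1ccc(Br)cc1)c1ccc([N+](=O)[O-])cc1` differs from compound 2 by 4-nitrophenyl in place of 2,3,4,5,6-pentafluorophenyl on a carbonyl carbon. Going by the values given here, no measured pair exchanges these two aryl groups, so only the carbonyl-carbon step offers a rough scale. For compound 4 a step of a 2.0-fold higher number from compound 2 to compound 4 (0.30 log units; within the scatter) is expected, leaving compound 4 with an estimated value of 20000 nM, within the range 5000 nM to 100000 nM.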

Compound 4, concentration for 50% growth inhibition: 10000 nM
For compound 4 the middle estimate is 2.0-fold (0.30 log units) above the measured one; measured number inside the range.
By their numbers in this assay, from the lowest: compound 3; then compounds 2 and 4 (each within the scatter of the next). At a limit, above all of these: compound 1.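

With 4-nitrophenyl in place of 2,3,4,5,6-pentafluorophenyl on the carbonyl carbon, this assay shows no change at the digits printed from compound 2 to compound 4 (within the scatter) and the two aryl groups are not told apart here. The stronger growth inhibition relative to 2,4-dihydroxyphenyl therefore does not belong to the pentafluorophenyl group alone, since 4-nitrophenyl also gives an at least 10-fold lower number from compound 1 to compound 4 (1.00 log units; beyond the scatter) as its step. That step is only a bound, as compound 1 stands at a limit: the limit of > 100000 nM in this assay, at which 1 of the 4 values shown sits.

Still open, on these data alone, is whether an aminophenyl or a carboxylic acid-bearing phenyl on the carbonyl carbon would hold this level. Also open, as far as these compounds go, is whether 4-bromophenyl in place of 4-bromobenzyl on the sulfur would lower the number with 4-nitrophenyl as it does with pentafluorophenyl.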